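Swapping a Methylsulfonyl for a Methylsulfanyl Group

This account rests on a few compounds, and the source may have more. Where it says the series, first, only, none or still open, it means among the compounds named here.

Measured compounds:
compound 1 `CC(C)OC(=O)N1CCC(Oc2ncnc3c2CCN3c2ccc(S(C)(=O)=O)cn2)CC1` gives 126 nM
compound 2 `CC(C)OC(=O)N1CCC(Oc2ncnc3c2CCN3c2ccc(C#N)cn2)CC1` gives 794 nM
compound 3 `CC(C)OC(=O)N1CCC(Oc2ncnc3c2CCN3c2ccc(S(C)(=O)=O)c(F)c2)CC1` gives 158 nM

In a functional assay on CHO-K1 cells for agonist activity at Glucose-dependent insulinotropic receptor (Homo sapiens), read by a luciferase reporter, with a stated time of 5 h (on this read-out higher numbers stand for an effect only at larger amounts of compound and lower numbers for an effect already at smaller amounts), compound 3 holds the second highest of the three numbers; one neighbouring number lies within the scatter, a 1.3-fold higher number from compound 1 to compound 3 (0.10 log units; within the scatter), the other beyond it, a 5.0-fold lower number from compound 2 to compound 3 (0.70 log units; beyond the scatter). Compound 4 `CSc1ccc(N2CCc3c(OC4CCN(C(=O)OC(C)C)CC4)ncnc32)cc1F` differs from compound 3 in one place: methylsulfanyl in place of methylsulfonyl on an aromatic carbon. Among the measured compounds shown here, no measured step makes this exact change. The nearest guide is the replacement of the same methylsulfonyl group by cyano, which gave a 6.3-fold higher number from compound 1 to compound 2 (0.80 log units; beyond the scatter), a modest rise. A smaller rise of similar kind is therefore expected for compound 4, a 2.8-fold higher number from compound 3 to compound 4 (0.45 log units; beyond the scatter). The estimate for compound 4 is 450 nM, with a range from 150 nM to 1500 nM.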

Compound 4, half-maximal effective concentration: 398 nM
Beside the measured number, compound 4's estimate is 1.1-fold (0.05 log units) above it; the measured number falls inside the stated range.
By their numbers in this assay, from the lowest: compounds 1 and 3 (each within the scatter of the next); then compounds 4 and 2 (each within the scatter of the next).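

Methylsulfonyl also proves hard to replace on the six-membered aromatic ring of carbon only: in this assay, methylsulfanyl gives a 2.5-fold higher number from compound 3 to compound 4 (0.40 log units; beyond the scatter). Comparing the whole group on the nitrogen gives a 2.0-fold lower number from compound 2 to compound 4 (0.30 log units; within the scatter) and a 3.2-fold higher number from compound 1 to compound 4 (0.50 log units; beyond the scatter), so compound 4 stays apart from the methylsulfonyl pyridine compound 1 but not from the nitrile compound 2. Nothing measured here explains the rise seen with methylsulfanyl. As far as these compounds go, it remains open how a methoxy group or an amine would behave at this position. Also open, from the compounds shown here alone, is how methylsulfanyl would behave on the aromatic ring of compound 1.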